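Methyl to trifluoromethyl at the limit of the assay

The compounds below may be only part of what the source reports. "The series", "measured", "known", "first", "only" and "open" are said of these compounds alone.

In a functional assay on B16-BL6 cells (Mus musculus) for cytotoxicity, read by MTT assay, with a stated time of 48 h (on this read-out higher numbers stand for weaker inhibition and lower numbers for stronger inhibition), compound 1 (`CNC(=O)c1ccc(Sc2ccc(NC(=S)Nc3cccc(C)c3)cc2)nc1`) gives > 100000 nM, which is a limit of the assay and not a number. Compound 2 (`CNC(=O)c1ccc(Sc2cccc(NC(=S)Nc3ccc(F)c(F)c3)c2)nc1`) gives a number, 58200 nM. Compound 3 (`CNC(=O)c1ccc(Sc2cccc(NC(=S)Nc3ccc(F)c(Cl)c3)c2)nc1`) gives > 100000 nM, again a limit.

Compound 4 (`CNC(=O)c1ccc(Sc2ccc(NC(=S)Nc3cccc(C(F)(F)F)c3)cc2)nc1`) carries trifluoromethyl in place of methyl on an aromatic carbon of compound 1, a change counted as trifluoromethyl in place of methyl on an aromatic carbon. Among the measured compounds shown here, no measured step makes this same change. For the measured compounds named here, the only step available is an at least 1.7-fold higher number from compound 2 to compound 3 (0.23 log units; that floor lies within the scatter), which is chloro in place of fluoro on an aromatic carbon, and that pair also differs from compound 1 elsewhere. The picture is otherwise set by the limit of > 100000 nM in this assay, at which 2 of the 3 values shown sit. No step beyond the scatter is therefore expected in this assay, in either direction, and a further limit would be no surprise. The estimate amounts to an expected at least 1.1-fold lower number from compound 1 to compound 4 (0.04 log units; that floor lies within the scatter). The value expected for compound 4 is 90000 nM, within an estimated range of 40000 nM to 160000 nM.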

Compound 4, half-maximal inhibitory concentration: 53100 nM
Beside the measured number, compound 4's estimate is 1.7-fold (0.23 log units) above it; low and high end bracket the measured number.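

Trifluoromethyl in place of methyl at this position, meta to a large group, gives an at least 1.8-fold lower number from compound 1 to compound 4 (0.27 log units; that floor lies within the scatter) in this assay. Among the compounds shown here, this is the first reading of any change at this position, and it moves the 3-substituted phenyl series from a limit of the assay to a number, since compound 4 has a measured value and compound 1 has only a limit. The full size of the step cannot be read, and its floor alone does not set it apart from the scatter, because its starting point is a limit and not a number: the limit of > 100000 nM in this assay, at which 2 of the 4 values shown sit.

On these data alone, whether a methoxy group, an amine or a carboxylic acid at this position would also give a number stays open. So does whether trifluoromethyl would give a comparable step on the core of compound 2.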